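From 2,4-difluorophenyl to 2-chlorophenyl: a distribution estimate

The source may hold more compounds than are shown below. What is called first, only, known or untested is meant among the compounds shown, and "the series" means these compounds.

- Compound 1 `CC(C)(C)N1CCC(c2cc(-c3ccc(F)cc3F)c3ccc(=O)n(-c4c(Cl)cccc4Cl)c3c2)CC1` gives 8.99 L/kg 
- Compound 2 `CC(C)(C)N1CCC(c2cc3c(ccc(=O)n3-c3c(Cl)cccc3Cl)c(-c3ccc(F)cc3F)n2)CC1` gives 23.8 L/kg 

In an in vivo ADME assay on the whole organism for pharmacokinetics, with Canis familiaris (Canis lupus familiaris) as the target (a lower number here means that more of the compound stays in the plasma, a higher number that more of the compound sits outside the plasma), compound 2 stands at 23.8 L/kg, the higher of the two numbers. Compound 1 comes nearest at 8.99 L/kg, and the gap between the two lies beyond the usual scatter.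

Compound 3 `CC(C)(C)N1CCC(c2cc3c(ccc(=O)n3-c3c(Cl)cccc3Cl)c(-c3ccccc3Cl)n2)CC1` has not yet been measured. It differs from compound 2 in one place: 2-chlorophenyl in place of 2,4-difluorophenyl on an aromatic carbon. In words, 2-chlorophenyl stands in place of 2,4-difluorophenyl on an aromatic carbon, next to the ring nitrogen.

Within the data shown here, no measured pair of compounds shows what a swap of this kind does to this assay, so the data offer no direct guide. The expectation therefore starts from compound 2 at 23.8 L/kg and assumes no step beyond the scatter, in either direction. The expected change is a 1.1-fold lower number from compound 2 to compound 3 (0.05 log units; within the scatter), which would stay within the scatter. For compound 3 the estimated value is 21 L/kg, with an expected range from 10 L/kg to 42 L/kg.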

Compound 3, volume of distribution at steady state: 15.1 L/kg
Compound 3: middle estimate off by 1.4-fold (0.14 log units), on the high side, within the range that was stated.
By their numbers in this assay, from the lowest: compounds 1, 3 and 2 (each within the scatter of the next, the first and the last beyond it).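

Among these compounds, this is the first measured swap at this position, and it gives a first reading of how much the group on this aromatic carbon, next to the ring nitrogen, matters in this assay: replacing 2,4-difluorophenyl with 2-chlorophenyl gives a 1.6-fold lower number from compound 2 to compound 3 (0.20 log units; within the scatter). Two fluorine atoms on the phenyl ring can thus give way to a single chlorine with no difference that can be told from the ordinary spread of repeated measurements, so on this evidence the two groups are interchangeable for this read-out on this core. Nothing at hand explains why the two numbers fall so close together, and a single pair cannot show whether the same would hold for other groups at this position.

The compounds shown leave open whether a phenyl ring carrying an amine or a carboxylic acid, or a saturated ring such as cyclohexyl, on this carbon would move the number beyond the scatter. They also leave open whether the same swap on the core of compound 1 would give a step of similar size.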